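Ring-amide substituent series: methyl in place of carbamoylethyl

A few compounds are considered here, and "the series" means these few. Any claim that something is new, unique, unknown or untested is made for them only; others in the source may bear on it.

The series shares one core and differs only on the amide-type nitrogen in the ring. Compound 1 `COc1c(C)cnc(CN2CC(=O)N(CC(C)C)c3c(Cl)nc(N)nc32)c1C` gives 70 nM in a functional assay on MCF7 cells (Homo sapiens) for inhibition; on this read-out higher numbers stand for weaker inhibition and lower numbers for stronger inhibition. Compound 2 `COc1c(C)cnc(CN2CC(=O)N(CCCC(C)C)c3c(Cl)nc(N)nc32)c1C` gives 3110 nM, a step of a 44-fold higher number from compound 1 to compound 2 (1.65 log units; beyond the scatter). Compound 3 `COc1c(C)cnc(CN2CC(=O)N(C(C)C(=O)NCCN(C)C)c3c(Cl)nc(N)nc32)c1C` gives 120 nM; it stands second highest of the three numbers, with compound 1 nearest, a 1.7-fold higher number from compound 1 to compound 3 (0.23 log units; within the scatter), and compound 2 furthest, a 26-fold lower number from compound 2 to compound 3 (1.41 log units; beyond the scatter).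

Compound 4 `COc1c(C)cnc(CN2CC(=O)N(C)c3c(Cl)nc(N)nc32)c1C` is not yet measured. The change is methyl in place of 1-((2-(dimethylamino)ethyl)carbamoyl)ethyl on an amide-type nitrogen in a ring. Within the data shown here, no measured step covers a group smaller than isobutyl on this nitrogen. Among the measured compounds shown here, the steps that bear on it show that a longer chain on this nitrogen raises the number strongly, as in a 44-fold higher number from compound 1 to compound 2 (1.65 log units; beyond the scatter), while the larger carbamoylethyl group of compound 3 stays close to compound 1, as in a 1.7-fold higher number from compound 1 to compound 3 (0.23 log units; within the scatter). A methyl group therefore is expected to give a number near those of compound 1 and compound 3, and the step of a 1.2-fold lower number from compound 3 to compound 4 (0.08 log units; within the scatter) is expected to lie within the scatter. Compound 4 is estimated at 100 nM, in a range from 30 nM to 400 nM.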

Compound 4, half-maximal inhibitory concentration: 2190 nM
The estimate for compound 4 lay 22-fold (1.34 log units) below the measured number; the measured number lies above the stated range.
By their numbers in this assay, from the lowest: compounds 1 and 3 (each within the scatter of the next); then compounds 4 and 2 (each within the scatter of the next).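

In this assay, the methyl group does not keep the low number at this amide-type nitrogen in a ring: the change gives an 18-fold higher number from compound 3 to compound 4 (1.26 log units; beyond the scatter), and measured against isobutyl it gives a 31-fold higher number from compound 1 to compound 4 (1.50 log units; beyond the scatter). Size on this nitrogen therefore does not act in one direction across these compounds, since methyl and 4-methylpentyl stand level, with a 1.4-fold lower number from compound 2 to compound 4 (0.15 log units; within the scatter), and the low numbers belong only to isobutyl and the much larger 1-((2-(dimethylamino)ethyl)carbamoyl)ethyl. No measurement offered here accounts for these steps.

Open, from the compounds shown here alone, is how the number changes with an ethyl or propyl chain on this nitrogen, between methyl and isobutyl. Also open, going by these compounds, is whether 1-((2-(dimethylamino)ethyl)carbamoyl)ethyl needs its terminal amine, which a simple hydroxyethyl amide or a carboxylic acid at that place would test.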